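This account rests on a few compounds, and the source may have more. Where it says the series, first, only, none or still open, it means among the compounds named here.

Compound 1 `COc1ccccc1/C=C/c1ccccc1O` carries a hydroxy group on one of its two aromatic rings. In a functional assay on MCF7 cells (Homo sapiens) for inhibition, read by MTT assay, with a stated time of 2 days (on this read-out lower numbers stand for stronger inhibition and higher numbers for weaker inhibition), compound 1 gives 17.9 ug/mL. Compound 2 `COc1cccc(/C=C/c2cccc(O)c2)c1` is built from the same atoms joined differently, and how its core differs from that of compound 1 is not broken down here. In this assay compound 2 gives 13 ug/mL, which lies within the usual scatter of the value for compound 1. Compound 3 `COc1ccccc1/C=C/c1ccccc1N` differs from compound 1 by amino in place of hydroxy on an aromatic carbon. For compound 3 this assay reports only a limit, > 100 ug/mL. Among the compounds with values here, the step of an at least 5.5-fold higher number from compound 1 to compound 3 (0.74 log units; beyond the scatter) weakens inhibition clearly, and the only further evidence is the limit of > 100 ug/mL in this assay, at which 1 of the 3 values shown sits. Compound 4 `COc1cccc(/C=C/c2cccc(N)c2)c1` is compound 2 altered in the same kind of way, by amino in place of hydroxy on an aromatic carbon; the place is not identical, since the amino group in compound 3 is ortho to a large group while in compound 4 it is meta to a large group. Compound 4 is expected to show a step of similar size, a 7.7-fold higher number from compound 2 to compound 4 (0.89 log units; beyond the scatter), resting on an at least 5.5-fold higher number from compound 1 to compound 3 (0.74 log units; beyond the scatter). Compound 4 is therefore estimated at about 100 ug/mL, most likely reported only as a limit.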

Compound 4, half-maximal inhibitory concentration: 34 ug/mL
Compound 4: middle estimate off by 2.9-fold (0.47 log units), on the high side; measured number below the stated range.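

Placing amino where hydroxy stood on an aromatic carbon raises the number on both cores in this assay, which means weaker inhibition each time, and on the core of compound 2 the full size can be read as a 2.6-fold higher number from compound 2 to compound 4 (0.42 log units; beyond the scatter). The direction of the change therefore carries over between these two cores, but whether its size carries over is a separate matter: the same change on two cores in this assay, an at least 5.5-fold higher number (0.74 log units; beyond the scatter) from compound 1 to compound 3 and a 2.6-fold higher number (0.42 log units; beyond the scatter) from compound 2 to compound 4; the limit leaves it open whether they differ. Compound 3 is reported only as a limit, > 100 ug/mL, and two pairs of compounds are too few to establish a rule for the whole series.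

The compounds shown leave open what other groups would do in place of hydroxy, such as a carboxylic acid, a methylamino group or a fluorine atom. They also leave open whether the same direction would hold on a core in which the methoxy group gives way to a longer chain, such as ethoxy.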